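The source may hold more compounds than are shown below. What is called first, only, known or untested is meant among the compounds shown, and "the series" means these compounds.

Measured compounds in a functional assay on NCI-H460 cells (Homo sapiens) for cytotoxicity, read by MTT assay; a higher number here means a weaker inhibitor, a lower number a stronger inhibitor:
compound 1, `Cc1nc(Nc2ccccc2)sc1C(=O)/C=C/c1ccc(Cl)cc1`: > 25000 nM, a limit of this assay.
compound 2, `Cc1nc(Nc2ccccc2)sc1C(=O)/C=C/c1ccccc1`: > 25000 nM, also a limit of this assay.

Compound 1 stands at the limit, not at a number, in this assay. Among the compounds with values here, the one step between measured compounds, a step that the two limits leave unreadable from compound 1 to compound 2, cannot be read because of the limit of > 25000 nM in this assay, at which 2 of the 2 values shown sit. The change from compound 1 to compound 3, `Cc1nc(Nc2ccc(Cl)c(Cl)c2)sc1C(=O)/C=C/c1ccc(Cl)cc1`, is 3,4-dichlorophenyl in place of phenyl on a nitrogen on an aromatic ring. Within the data shown here, no measured step touches this position, and the single step at another position gives no size at all. The expectation is therefore that compound 3 behaves like compound 1 and compound 2 and again reaches only the limit, the expected step being a step that the limit leaves unreadable from compound 1 to compound 3. Compound 3 is estimated in this assay at 30000 nM, with a range from 8000 nM to 100000 nM, most likely reported as a limit rather than a number.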

Compound 3, half-maximal inhibitory concentration: > 25000 nM
Compound 3 gave a limit, no number; the forecaster's own chance of this, stated with the estimate: 70%; the middle value does not contradict the limit.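

The step from compound 1 to compound 3 cannot be read, as both are limits in this assay, not numbers: the limit of > 25000 nM in this assay, at which 3 of the 3 values shown sit.

The compounds shown leave open whether 3,4-dichlorophenyl in place of phenyl changes cytotoxicity at all, and whether any compound of this series gives a number in this assay.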